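A few compounds are considered here, and "the series" means these few. Any claim that something is new, unique, unknown or untested is made for them only; others in the source may bear on it.

Measured compounds and their values:
- Compound 1 `CC(=O)N1CCN(c2cc(-c3cc(Cl)c4c(N)ncnn34)ccc2C(F)(F)F)C(=O)C1(C)C` gives 95%
- Compound 2 `CC(=O)N1CCN(c2cc(-c3cc(Cl)c4c(N)ncnn34)ccc2C(C)O)C(=O)C1(C)C` gives 100%
- Compound 3 `CC(=O)N1CCN(c2cc(-c3cc(Cl)c4c(N)ncnn34)ccc2C#N)C(=O)C1(C)C` gives 90%

All three values come from an ADME assay on microsomes from liver (Homo sapiens) for metabolic stability, read by LC-MS, using NADPH, with stated times of 6 min and 10 min, tested at 0.5 uM (a lower number here means that less of the compound is left, a higher number that more of the compound is left), and the compounds differ only in one group on an aromatic carbon. Compound 3 stands at 90% in this assay and cannot be ranked against the others, since both steps that reach it stay within the scatter: a number 5 percentage points lower from compound 1 to compound 3 (within the scatter) and a number 10 percentage points lower from compound 2 to compound 3 (within the scatter).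

Compound 4 `CC(=O)N1C[C@H](C)N(c2cc(-c3cc(Cl)c4c(N)ncnn34)ccc2C#N)C(=O)C1(C)C` differs from compound 3 by one change, methyl in place of hydrogen on a saturated ring carbon. Among the compounds with values here, no measured step touches that ring. The remaining step, a number 5 percentage points higher from compound 1 to compound 2 (within the scatter), is also a swap on the aromatic carbon, so these steps bear on the new change only indirectly. Within the data shown here, they show only that three different groups at that one place gave values within the scatter of each other.

No step beyond the scatter is therefore expected, and the estimated step is no change at the digits printed from compound 3 to compound 4 (within the scatter). Compound 4 is expected at 90%, with an estimated range from 78% to 100%.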

Compound 4, percent of the compound remaining: 99%
Compound 4: the middle estimate sits 9 percentage points below what was measured; the measured number falls inside the stated range.
By their numbers in this assay, from the lowest: compounds 3, 1, 4 and 2 (each within the scatter of the next).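

In this assay the result is a number 9 percentage points higher from compound 3 to compound 4 (within the scatter), and this is the first change shown away from the aromatic carbon. The earlier compounds shown here varied only the group at that one place, whereas this step shows that a saturated ring carbon next to the ring nitrogen can carry a methyl with no readable shift in how much compound is left. Nothing measured here offers an explanation for this result.

Open, on these data alone, is whether a longer chain such as ethyl, or a hydroxymethyl or aminomethyl group, on this same ring carbon would also stay within the scatter, and whether the methyl in its opposite spatial arrangement would behave alike. Also open, as far as these compounds go, is whether this methyl gives the same picture with trifluoromethyl or 1-hydroxyethyl on the aromatic carbon in place of cyano.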